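This account rests on a few compounds, and the source may have more. Where it says the series, first, only, none or still open, it means among the compounds named here.

Working notes on the purine series

Compound 1 `CCCn1c(-c2ccccc2)nc2c(NC3CCC3)ncnc21` gives 264 nM in an assay on CHO cells for displacement of a labelled ligand from adenosine receptor A3 (Homo sapiens), read by scintillation counting, with a stated time of 3 h; a higher number here means a weaker inhibitor, a lower number a stronger inhibitor. Compound 2 `CCCn1c(-c2ccccc2)nc2c(NC3CCCCC3)ncnc21` gives 2360 nM in this assay. Among the compounds with values here, the one measured step, an 8.9-fold higher number from compound 1 to compound 2 (0.95 log units; beyond the scatter), goes with the cyclohexyl in place of the cyclobutyl on a nitrogen on an aromatic ring. Within the data shown here, compound 2 thus stands at the higher of the two numbers known so far, its only neighbour being compound 1 with the lower number.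

Compound 3 `CCCn1c(-c2ccccc2)nc2c(N)ncnc21` differs from compound 2 by hydrogen in place of cyclohexyl on a nitrogen on an aromatic ring, which means the whole ring on that nitrogen is taken away and nothing but a hydrogen remains. Among the measured compounds shown here, the only step that bears on this is an 8.9-fold higher number from compound 1 to compound 2 (0.95 log units; beyond the scatter), a modest step that shows the larger ring on this nitrogen giving the higher number. That step tells how two rings compare, not how a bare amino compares with either, so the direction of the step to compound 3 is open. An expectation of roughly a level number is taken, with wide uncertainty: compound 3 is estimated at 1500 nM in this assay, between 200 nM and 10000 nM, which is an expected step of a 1.6-fold lower number from compound 2 to compound 3 (0.20 log units; within the scatter).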

Compound 3, inhibition constant: 9280 nM
For compound 3 the middle estimate is 6.2-fold (0.79 log units) below the measured one; the range from low to high includes it.
By their numbers in this assay, from the lowest: compound 1; then compound 2; then compound 3.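

Taking the ring off this nitrogen altogether raises the number in this assay from either ring-bearing compound: the cyclohexyl to hydrogen change gives (a 3.9-fold higher number from compound 2 to compound 3 (0.59 log units; beyond the scatter)), and the cyclobutyl to hydrogen change gives (a 35-fold higher number from compound 1 to compound 3 (1.55 log units; beyond the scatter)). Within the data shown here, the earlier pair compared only two rings; these steps set both below the bare amino, and the cost of losing the ring is clearly larger from cyclobutyl than from cyclohexyl. The order among these three is therefore not a simple trend with the amount of carbon on the nitrogen, since compound 1 has the lowest number, compound 2 with the larger ring lies higher, and compound 3 with no ring lies highest, and nothing available explains this order.

Still open, from the compounds shown here alone, is where the lowest number falls among other groups on this nitrogen, such as cyclopentyl, cyclopropyl, an open butyl chain or a tetrahydropyranyl ring carrying an oxygen. Also open, going by these compounds, is whether the same order among cyclobutyl, cyclohexyl and hydrogen would hold with an ethyl chain in place of the propyl on the shared core.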